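The compounds below may be only part of what the source reports. "The series", "measured", "known", "first", "only" and "open" are said of these compounds alone.

Compound 3 `CCN(CC)c1ccc2cc(C(=O)c3ccc(N4CCN(C(=O)CN5CCN(S(=O)(=O)c6ccc(F)cc6)CC5)CC4)cc3)oc2c1` carries a (4-fluorophenyl)sulfonyl group on an amine nitrogen in a ring. In a functional assay on A549 cells (Homo sapiens) for cytotoxicity, read by MTT assay, with a stated time of 48 h (on this read-out lower numbers stand for stronger inhibition and higher numbers for weaker inhibition), compound 3 gives 33200 nM, the highest of the two numbers shown. Its nearest neighbour is compound 1 `CCN(CC)c1ccc2cc(C(=O)c3ccc(N4CCN(C(=O)CN5CCN(C(=O)CCl)CC5)CC4)cc3)oc2c1`, which in this assay gives 3060 nM; the step of an 11-fold higher number from compound 1 to compound 3 (1.04 log units; beyond the scatter). Compound 2 `CCN(CC)c1ccc2cc(C(=O)c3ccc(N4CCN(C(=O)CN5CCN(S(=O)(=O)c6ccc(OC(F)(F)F)cc6)CC5)CC4)cc3)oc2c1` gives > 40000 nM in this assay, which is the limit of > 40000 nM in this assay, at which 1 of the 3 values shown sits, and not a number. The step of an at least 1.2-fold lower number from compound 2 to compound 3 (0.08 log units; that floor lies within the scatter) stays within the scatter.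

Compound 4 `CCN(CC)c1ccc2cc(C(=O)c3ccc(N4CCN(C(=O)CN5CCN(Cc6ccc(C#N)cc6)CC5)CC4)cc3)oc2c1` has not yet been measured. It differs from compound 3 in one place: 4-cyanobenzyl in place of (4-fluorophenyl)sulfonyl on an amine nitrogen in a ring. Among the compounds with values here, of the measured steps, only the one from compound 1 to compound 3 touches this same amine nitrogen in a ring, and it was large; the step from compound 2 to compound 3 sits on an aromatic carbon and was small. Within the data shown here, the entering 4-cyanobenzyl group matches neither of the two groups compared in those steps, so the direction cannot be read from them; the single precedent at this nitrogen shows only that the number can move by a large amount there. Compound 4 is therefore expected to give 15000 nM in this assay, with a range from 4000 nM to 40000 nM. The expected step is a 2.2-fold lower number from compound 3 to compound 4 (0.35 log units; beyond the scatter), with wide uncertainty.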

Compound 4, half-maximal inhibitory concentration: 17400 nM
Compound 4: the middle estimate sits 1.2-fold (0.06 log units) below what was measured; the measured number falls inside the stated range.
By their numbers in this assay, from the lowest: compound 1; then compounds 4 and 3 (each within the scatter of the next). At a limit, above all of these: compound 2.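

At the amine nitrogen in a ring, replacing the (4-fluorophenyl)sulfonyl group with 4-cyanobenzyl gives a 1.9-fold lower number from compound 3 to compound 4 (0.28 log units; within the scatter) in this assay, so the sulfonyl link and the benzyl link, each carrying one six-membered aromatic ring, are not told apart in this assay. Within the data shown here, the earlier compounds showed a large move at this nitrogen for only one aromatic group; the second aromatic group also stands clear of the (chloromethyl)carbonyl group, with a 5.7-fold higher number from compound 1 to compound 4 (0.75 log units; beyond the scatter), although that step is smaller than the one printed for the sulfonyl compound. The value of compound 2 remains a limit and not a number, so it adds no measured size to this comparison: the limit of > 40000 nM in this assay, at which 1 of the 4 values shown sits.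

The compounds shown leave open whether the separation of compound 1 from compounds 3 and 4 depends on the chlorine of its (chloromethyl)carbonyl group or on the carbonyl attached to the nitrogen, which an acetyl group at that nitrogen would help to decide. They also leave open how a plain benzyl group without the nitrile, or a free amine at the same nitrogen, would read in this assay.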